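The source may hold more compounds than are shown below. What is called first, only, known or untested is meant among the compounds shown, and "the series" means these compounds.

Compound 1 `Cc1ccc(/C=N/NC(=O)COc2cccc3ccccc23)cc1` is the most lipophilic of the three measured compounds in a physicochemical assay for lipophilicity, measured as octanol-water partition (on this read-out higher numbers stand for higher lipophilicity and lower numbers for lower lipophilicity), where compound 1 gives 4.49. Compound 3 `C/C(=N\NC(=O)COc1cccc2ccccc12)c1ccc(Cl)cc1` comes nearest with 4.17, and compound 2 `O=C(COc1cccc2ccccc12)N/N=C/c1ccc([N+](=O)[O-])cc1` lies furthest away with 3.97. Going by the values given here, the one measured step that changes a single place, a number 0.52 log units lower from compound 1 to compound 2 (beyond the scatter), shows how the read-out falls when the methyl of compound 1 is exchanged.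

Compound 4 `O=C(COc1cccc2ccccc12)N/N=C/c1ccccc1O` has not been measured yet. It differs from compound 1 in one place: 2-hydroxyphenyl in place of 4-methylphenyl on a carbon with a double bond to nitrogen. Here the 4-methylphenyl that leaves is the same group that was altered in the step to compound 2, and the 2-hydroxyphenyl that enters brings a hydroxyl in its stead. That step was modest but clearly beyond the scatter, and a hydroxyl is generally a stronger pull downward on this read-out than a nitro, so a somewhat larger fall is expected for compound 4, with the step from compound 1 expected to be a number 0.99 log units lower from compound 1 to compound 4 (beyond the scatter). Compound 4 is therefore expected to give about 3.5, most likely between 3 and 4.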

Compound 4, partition coefficient: 3.73
Compound 4: the middle estimate sits 0.23 log units below what was measured, and the stated range covers the measured number.
By their numbers in this assay, from the lowest: compounds 4, 2 and 3 (each within the scatter of the next, the first and the last beyond it); then compound 1.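

The change at this carbon gives a number 0.76 log units lower from compound 1 to compound 4 (beyond the scatter) in this assay, even though the group that leaves and the group that enters both have 7 heavy atoms and one six-membered aromatic ring; the entering group adds 1 hydrogen-bond donor and 1 hydrogen-bond acceptor. A clear fall here therefore comes with no change in heavy-atom count, and both single changes made to the 4-methylphenyl of compound 1 lower the number, with compound 2 at 3.97 and compound 4 at 3.73 lying within the usual scatter of each other. No measurement at hand explains this fall.

A plain phenyl on this carbon would help separate what losing the methyl contributes from what gaining the hydroxyl contributes. As far as these compounds go, how an amine or a carboxylic acid on this aromatic ring would compare remains open.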